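The compounds below may be only part of what the source reports. "The series", "measured", "known", "first", "only" and "open" are said of these compounds alone.

Measured compounds:
compound 1, `O=C(/C=C/c1ccc(O)cc1)c1c(O)cccc1OCc1ccccc1`: > 30000 nM
compound 2, `CC(C)(C)CCOc1cccc(O)c1C(=O)/C=C/c1ccc(C(=O)O)cc1`: 8450 nM
compound 3, `CC(C)(C)CCOc1cccc(O)c1C(=O)/C=C/c1ccc(S(N)(=O)=O)cc1`: 3300 nM

In a functional assay on ACHN cells (Homo sapiens) for antiproliferative activity, read by sulforhodamine B assay (a lower number here means a stronger inhibitor of growth, a higher number a weaker inhibitor of growth), compound 1 reaches only a limit of the assay, (the limit of > 30000 nM in this assay, at which 1 of the 3 values shown sits), and no number stands for it. Compound 2 gives 8450 nM in this assay, and compound 3 gives 3300 nM. Among the compounds with values here, the one step measured between compounds that differ in a single place, a 2.6-fold lower number from compound 2 to compound 3 (0.41 log units; beyond the scatter), concerns a group on the far ring and not the ether chain.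

Compound 4, `CCC(CC)COc1cccc(O)c1C(=O)/C=C/c1ccc(O)cc1`, differs from compound 1 by pentan-3-yl in place of phenyl on a saturated chain carbon bound to an oxygen on an aromatic ring. Within the data shown here, no measured step covers exactly this change. What the numbers do show is that compound 1, with benzyloxy, sits at the limit. The two compounds whose ether carries a saturated branched chain give measurable values: compound 2 gives 8450 nM and compound 3 gives 3300 nM, though both also carry a different group on the far ring. Compound 4 is expected to move from the limit toward a measurable value, a step of an at least 2.0-fold lower number from compound 1 to compound 4 (0.30 log units; that floor lies within the scatter) as estimated. For compound 4 the estimate in this assay is 15000 nM, expected to fall between 4000 nM and 60000 nM.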

Compound 4, concentration for 50% growth inhibition: 3370 nM
Compound 4: the middle estimate sits 4.5-fold (0.65 log units) above what was measured; the measured number lies below the stated range.
By their numbers in this assay, from the lowest: compounds 3 and 4 (each within the scatter of the next); then compound 2. At a limit, above all of these: compound 1.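

Within the data shown here, until now, the only step between compounds differing in one place lay on the far ring, so nothing isolated the effect of changing the ether group. Compound 1 and compound 4 share the core and the hydroxy group on the far ring, so the change from phenyl to pentan-3-yl on a saturated chain carbon bound to an oxygen on an aromatic ring stands alone, and in this assay it gives an at least 8.9-fold lower number from compound 1 to compound 4 (0.94 log units; beyond the scatter). That step is a floor and not a full size, since compound 1 sits at a limit of the assay: the limit of > 30000 nM in this assay, at which 1 of the 4 values shown sits.

Phenyl is a ring and pentan-3-yl is an open branched group, so this one pair cannot tell whether a saturated ring such as cyclohexyl would read like the open group, or how a straight hexyl chain or a chain carrying an amine would read. Going by these compounds, it also remains open whether the far-ring difference seen between the carboxy and sulfamoyl groups would hold with a 2-ethylbutoxy group on the core.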